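From compound 2 to compound 4: an added amine chain

The source may hold more compounds than are shown below. What is called first, only, known or untested is meant among the compounds shown, and "the series" means these compounds.

In an ADME assay for permeability, using PAMPA, with a stated time of 4 h, at pH 5.5 (a lower number here means that the compound crosses the layer more slowly, a higher number that the compound crosses the layer faster), compound 2 (`CN(C[C@H]1Cc2ncccc2CN1)[C@H]1CCCc2cccnc21`) gives 460 nm/s as its number. Compound 3 (`CN(C[C@@H]1Cc2ncccc2CN1)[C@H]1CCCc2cccnc21`) gives 230 nm/s and sits level with it (a 2.0-fold lower number from compound 2 to compound 3 (0.30 log units; within the scatter)). Compound 1 (`NCCCCN(C[C@H]1Cc2ncccc2CN1)[C@H]1CCCc2cccnc21`) gives 17 nm/s and lies far lower. That large step (a 27-fold higher number from compound 1 to compound 2 (1.43 log units; beyond the scatter)) comes with hydrogen in place of 3-aminopropyl.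

Compound 4 (`NC/C=C\CN(C[C@H]1Cc2ncccc2CN1)[C@H]1CCCc2cccnc21`) brings 3-aminoprop-1-en-1-yl in place of hydrogen on a saturated chain carbon bound to an amine nitrogen as its change: 3-aminoprop-1-en-1-yl in place of hydrogen on a saturated chain carbon bound to an amine nitrogen. This group carries a double bond that 3-aminopropyl lacks, yet compound 1 remains the closest guide, so the large step, read in reverse, is what counts. A large fall is expected (a 23-fold lower number from compound 2 to compound 4 (1.36 log units; beyond the scatter)) in this assay for this change. The estimated value for compound 4 is 20 nm/s within an expected range from 7 nm/s to 55 nm/s overall.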

Compound 4, apparent permeability: 28 nm/s
The estimate for compound 4 lay 1.4-fold (0.15 log units) below the measured number; measured number inside the range.
By their numbers in this assay, from the lowest: compounds 1 and 4 (each within the scatter of the next); then compounds 3 and 2 (each within the scatter of the next).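

A second chain carrying an amine at this position again brings a large fall in this assay (a 16-fold lower number from compound 2 to compound 4 (1.22 log units; beyond the scatter)), so compound 1 is not a lone case. Putting 3-aminoprop-1-en-1-yl in place of 3-aminopropyl moves the number only within the scatter (a 1.6-fold higher number from compound 1 to compound 4 (0.22 log units; within the scatter)), so the double bond makes no readable difference here. The data shown give no reason for the fall. On these data alone, whether a plain propyl chain, with no amine, would bring the same fall in this assay or a smaller one stays open, as does the outcome for a longer amine chain.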